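The compounds below may be only part of what the source reports. "The series", "measured", "known", "first", "only" and "open" are said of these compounds alone.

Working notes on the series. Within the data shown here, two analogues have numbers so far in a functional assay on A549 cells (Homo sapiens) for antiproliferative activity, read by MTT assay, with a stated time of 24 h; a lower number here means a stronger inhibitor, a higher number a weaker inhibitor. Compound 1 `COc1cc(C(=O)/C=C/c2cc(-c3cc(OC)c(OC)c(OC)c3)n3nc(-c4ccccc4)cc3n2)cc(OC)c1OC` gives 20500 nM in this assay. Compound 2 `COc1ccc(/C=C/C(=O)c2cc(-c3ccc(OC)c(OC)c3)n3nc(-c4ccccc4)cc3n2)cc1` gives 19300 nM in this assay. Of the two numbers, that of compound 2 is the smaller as read, but the gap to compound 1 is within the scatter and supports no ranking between them. Among the measured compounds shown here, no pair among the measured compounds differs in a single place, so no step of that kind is available.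

Compound 3 `COc1ccc(-c2cc(C(=O)/C=C/c3ccc(C)cc3)nc3cc(-c4ccccc4)nn23)cc1OC` has not been measured in this assay. Its difference from compound 2 is methyl in place of methoxy on an aromatic carbon, para to a large group. Nothing in the two measured points isolates this position, so the expectation rests only on the closeness of compound 1 and compound 2 and on the smallness of the change. The expected step is a 1.0-fold higher number from compound 2 to compound 3 (0.02 log units; within the scatter), with no direction beyond the scatter. Compound 3 is estimated at 20000 nM in this assay, within a range from 8000 nM to 50000 nM.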

Compound 3, half-maximal inhibitory concentration: 22200 nM
The estimate for compound 3 lay 1.1-fold (0.05 log units) below the measured number; the range from low to high includes it.
By their numbers in this assay, from the lowest: compounds 2, 1 and 3 (each within the scatter of the next).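

Among these compounds, the step of a 1.2-fold higher number from compound 2 to compound 3 (0.06 log units; within the scatter) in this assay is the first comparison that isolates a single place, and it shows that methyl in place of methoxy on this aromatic carbon, para to a large group, gives no difference that can be separated from the scatter. For this pair, then, 4-methoxyphenyl and 4-methylphenyl on the (2-(aryl)ethenyl)carbonyl side cannot be told apart, and the oxygen and the hydrogen-bond acceptor counted on the methoxy are not needed to keep the number where compound 2 has it. No independent measurement bears on this result, so the closeness of the two numbers stays a bare observation.

Steps from compound 1 to the other two compounds cannot be read, since it differs from each in more than one place, so its substitution pattern remains untested as a separate change. Also open, going by these compounds, is whether an amine, a carboxylic acid or a longer alkoxy chain at this same position would stay within the scatter of compound 2 or move the number beyond it.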